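The source may report more compounds than this note shows. Statements on the series, on what has been measured and on what is new or still open speak of the compounds shown alone.

Working notes on the series. Two compounds of the shared core have been run in a functional assay on HepG2 cells (Homo sapiens) for antiproliferative activity, read by MTT assay, with a stated time of 48 h; on this read-out higher numbers stand for weaker inhibition and lower numbers for stronger inhibition. Compound 1 `Cc1ccc(Cl)cc1-n1nncc1CN1C(=O)C2(C(C#N)=C(N)Oc3c2c2nc4ccccc4nc2c2ccccc32)c2ccccc21` carries a methyl-chlorophenyl group on its triazole. In this assay compound 1 gives only a limit of > 50000 nM, not a number. Compound 2 `N#CC1=C(N)Oc2c(N)cc3nc4ccccc4nc3c2C12C(=O)N(Cc1cnnn1-c1ccc(F)cc1)c1ccccc12` differs in its core, which bears an amino group, and carries a 4-fluorophenyl on the triazole. In this assay compound 2 likewise gives only a limit of > 50000 nM, not a number. Compound 2 therefore stands at the same limit as compound 1, (the limit of > 50000 nM in this assay, at which 2 of the 2 values shown sit), so no order between the two can be drawn. For the measured compounds named here, no step between measured compounds with a single change is available.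

Compound 3 `CCOc1ccc(-n2nncc2CN2C(=O)C3(C(C#N)=C(N)Oc4c(N)cc5nc6ccccc6nc5c43)c3ccccc32)cc1` is not yet measured. It is compound 2 with ethoxy in place of fluoro on an aromatic carbon; cut one bond further out, the change reads 4-fluorophenyl to 4-ethoxyphenyl on the triazole. Because compound 2 sits at the limit > 50000 nM, no shift beyond the scatter is expected from compound 2 to compound 3, and compound 3 is expected to stay near the limit as well, estimated at 60000 nM with a range of 20000 nM to 200000 nM. The expected step that the limit leaves unreadable from compound 2 to compound 3 is thus essentially none.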

Compound 3, half-maximal inhibitory concentration: > 50000 nM
Compound 3: no number, only a limit; the forecaster's own chance of this, stated with the estimate: 75%; the middle value does not contradict the limit.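

Compound 3, like compound 2, gives only a limit and not a number, so the change from 4-fluorophenyl to 4-ethoxyphenyl yields no readable step between compound 2 and compound 3: the limit of > 50000 nM in this assay, at which 3 of the 3 values shown sit.

The compounds shown leave open whether any member of the series reaches a measurable value and how these two groups on the triazole would compare.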